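Pyrrolidine substituent change: carbamoyl replacing methyl

A few compounds are considered here, and "the series" means these few. Any claim that something is new, unique, unknown or untested is made for them only; others in the source may bear on it.

Three compounds share the core and differ only at the saturated ring carbon of the five-membered non-aromatic ring. Compound 3 `C[C@@H]1CC(c2cnc3c(C#N)nn([C@H](C)c4ccc(Cl)cc4Cl)c3n2)=CC[C@@H]1N1CCC[C@H]1C` gives 44 nM in an assay on CCRF-CEM cells for antagonist activity at C-C chemokine receptor type 4 (Homo sapiens), read by CellTiter-Glo, with stated times of 30 min and 60 min, in the presence of a further agent that is not named here (a higher number here means a weaker inhibitor, a lower number a stronger inhibitor), the lowest of the three numbers. Compound 1 `C[C@@H]1CC(c2cnc3c(C#N)nn([C@H](C)c4ccc(Cl)cc4Cl)c3n2)=CC[C@@H]1N1CCC[C@H]1CO` gives 70 nM, and the step of a 1.6-fold lower number from compound 1 to compound 3 (0.20 log units; within the scatter) lies within the scatter. Compound 2 `C[C@@H]1CC(c2cnc3c(C#N)nn([C@H](C)c4ccc(Cl)cc4Cl)c3n2)=CC[C@@H]1N1CCC[C@H]1C(C)(C)O` gives 1200 nM, and the step of a 27-fold lower number from compound 2 to compound 3 (1.44 log units; beyond the scatter) is large; likewise a 17-fold higher number from compound 1 to compound 2 (1.23 log units; beyond the scatter).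

Compound 4 `C[C@@H]1CC(c2cnc3c(C#N)nn([C@H](C)c4ccc(Cl)cc4Cl)c3n2)=CC[C@@H]1N1CCC[C@H]1C(N)=O` is not yet measured. The change is carbamoyl in place of methyl on a saturated ring carbon. The measured steps show that a small hydroxy-bearing group is tolerated while a bulkier hydroxy-bearing group is not. Carbamoyl adds a donor and an acceptor and is between those two in size, so a step weaker than compound 2 but beyond the scatter toward a higher number is expected, namely a 4.5-fold higher number from compound 3 to compound 4 (0.66 log units; beyond the scatter). Compound 4 is therefore estimated at 200 nM, with a range from 60 nM to 700 nM.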

Compound 4, half-maximal inhibitory concentration: 1380 nM
Beside the measured number, compound 4's estimate is 6.9-fold (0.84 log units) below it, and the stated range ends below it.
By their numbers in this assay, from the lowest: compounds 3 and 1 (each within the scatter of the next); then compounds 2 and 4 (each within the scatter of the next).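

In this assay, carbamoyl at this saturated ring carbon gives a 1.2-fold higher number from compound 2 to compound 4 (0.06 log units; within the scatter), so the large loss seen with 1-hydroxy-1-methylethyl is not confined to that group. The step from the methyl of compound 3 is a 31-fold higher number from compound 3 to compound 4 (1.50 log units; beyond the scatter), and the step from the hydroxymethyl of compound 1 is a 20-fold higher number from compound 1 to compound 4 (1.29 log units; beyond the scatter), so a hydroxymethyl group is tolerated here while carbamoyl, in these compounds, is not. No measurement available for this series accounts for these steps.

The compounds shown leave open whether an aminomethyl group, a carboxylic acid or an ethyl group at this carbon would fall with compound 3 and compound 1 or with compound 2 and compound 4. They also leave open how an N-methylcarbamoyl group would compare with carbamoyl at this carbon.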